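Replacing 2-fluorophenyl with cyclohexyl: working notes

The source may hold more compounds than are shown below. What is called first, only, known or untested is meant among the compounds shown, and "the series" means these compounds.

Measured in a functional assay on NB-4 cells (Homo sapiens) for inhibition, read by XTT assay, with a stated time of 48 h; a higher number here means a weaker inhibitor, a lower number a stronger inhibitor:
- compound 1 `COc1ccc(C(=O)/C(=C/c2ccc(C(F)(F)F)cc2)CC(C)C)cc1`: 12600 nM
- compound 2 `C=C(C(=O)c1ccc(OC)cc1)C(OC(C)=O)c1ccccc1F`: 9500 nM

Within the data shown here, only two values are available so far, and they lie within the scatter of each other. Compound 2, at 9500 nM, therefore cannot be separated from compound 1, at 12600 nM.

The next compound to be measured is compound 3 `C=C(C(=O)c1ccc(OC)cc1)C(OC(C)=O)C1CCCCC1`. It carries cyclohexyl in place of 2-fluorophenyl on a saturated chain carbon bound to a double-bonded chain carbon and an oxygen next to a carbonyl group.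

Among the measured compounds shown here, no measured pair differs in one place only, so the data give no direct guide to this change. Compounds 1 and 2 differ in more than one place yet remain within the scatter of each other, which gives weak support for expecting little movement. The expected step of a 1.2-fold higher number from compound 2 to compound 3 (0.06 log units; within the scatter) lies within the scatter, with no firm direction. In this assay, the estimate for compound 3 is 11000 nM, with an expected range of 4500 nM to 27000 nM.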

Compound 3, half-maximal inhibitory concentration: 10500 nM
For compound 3 the middle estimate is 1.0-fold (0.02 log units) above the measured one, within the range that was stated.
By their numbers in this assay, from the lowest: compounds 2, 3 and 1 (each within the scatter of the next).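

In this assay, among these compounds, cyclohexyl in place of 2-fluorophenyl on a saturated chain carbon bound to a double-bonded chain carbon and an oxygen next to a carbonyl group gives a 1.1-fold higher number from compound 2 to compound 3 (0.04 log units; within the scatter) and provides the first comparison that differs in one place only. At this position, the six-membered aromatic ring bearing fluorine and the six-membered non-aromatic ring of carbon only therefore cannot be told apart in this assay, so the aromatic ring and its fluorine are not shown to be needed for the activity read here. No measurement is available that bears on why the two groups read alike.

Going by these compounds, whether an amine, a carboxylic acid or a longer chain at this same saturated chain carbon would move the number beyond the scatter remains open. A single exchange also leaves open how far this tolerance extends to other groups at this position, and it says nothing about changes elsewhere on the shared core.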